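A few compounds are considered here, and "the series" means these few. Any claim that something is new, unique, unknown or untested is made for them only; others in the source may bear on it.

Among the compounds with values here, compound 3 `O=C(Nc1ccc(C(F)(F)F)cc1)c1csc(Oc2c(Cl)cccc2Cl)n1` gives 870 nM in an assay on CHO cells, read by calcium flux (a lower number here means a stronger inhibitor, a higher number a weaker inhibitor), the highest of the two numbers so far; nearest is compound 1 `CC(C)(C)c1ccc(NC(=O)c2csc(Cc3c(Cl)cccc3Cl)n2)cc1`, which in this assay gives 570 nM, a gap within the scatter. Compound 2 `O=C(Nc1ccc(C(F)(F)F)cc1)c1csc(-c2c(Cl)cccc2Cl)n1` reaches only a limit of the assay, > 4000 nM. Within the data shown here, the one measured step that touches the same place is an at least 4.5-fold lower number from compound 2 to compound 3 (0.66 log units; beyond the scatter), a bound rather than a number because the limit of > 4000 nM in this assay, at which 1 of the 3 values shown sits, holds one of the two values.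

Compound 4 `O=C(Nc1ccc(C(F)(F)F)cc1)c1csc(Nc2ccccc2Cl)n1` differs from compound 3 as follows: (2-chlorophenyl)amino in place of 2,6-dichlorophenoxy on an aromatic carbon. Among the measured compounds shown here, no measured pair covers an amino in place of an oxy bridge, nor the loss of one chlorine; the only guidance is that the bridged ring of compound 3 gave a lower number than the directly attached ring of compound 2, and compound 4 keeps a one-atom bridge. A step within the scatter in either direction is therefore expected, a 1.5-fold lower number from compound 3 to compound 4 (0.16 log units; within the scatter). For compound 4 the estimate in this assay is 600 nM, within 200 nM to 2000 nM.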

Compound 4, half-maximal inhibitory concentration: 1750 nM
Estimate against measurement, compound 4: 2.9-fold (0.46 log units) below, and the stated range covers the measured number.
By their numbers in this assay, from the lowest: compounds 1, 3 and 4 (each within the scatter of the next, the first and the last beyond it). At a limit, above all of these: compound 2.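

In this assay, an amino bridge on this aromatic carbon reads much like the oxy bridge: a 2.0-fold higher number from compound 3 to compound 4 (0.30 log units; within the scatter), a step that stays within the scatter even though (2-chlorophenyl)amino brings a hydrogen-bond donor and one chlorine fewer than 2,6-dichlorophenoxy. The advantage over the directly attached ring of compound 2 therefore appears with a second bridge, as an at least 2.2-fold lower number from compound 2 to compound 4 (0.35 log units; beyond the scatter). This step is a bound rather than a number: the limit of > 4000 nM in this assay, at which 1 of the 4 values shown sits.

Still open, going by these compounds, is which of the two changes in compound 4 carries the step, the amino bridge or the loss of one chlorine, a question that a (2,6-dichlorophenyl)amino group would address. Also open, on these data alone, is how a thioether bridge or a two-carbon chain would read at this place.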